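A few compounds are considered here, and "the series" means these few. Any claim that something is new, unique, unknown or untested is made for them only; others in the source may bear on it.

Measured so far in a toxicity assay on THP-1 cells (Homo sapiens) for inhibition; a higher number here means that more compound is tolerated, a lower number that less compound is tolerated:
- Compound 1 `COc1ccc(-c2cnc(NC(=O)c3ncc[nH]3)n2C)cc1`: > 100000 nM (a limit)
- Compound 2 `COc1ccc(-c2cnc(NC(=O)c3ccc(C)cc3)n2C)cc1`: > 100000 nM (a limit)

Compound 2 stands only at a limit, > 100000 nM, so no number is available for it. Compound 1 is also only a limit, at > 100000 nM. Among the compounds with values here, the one measured step is a step that the two limits leave unreadable from compound 1 to compound 2, so it offers no size to carry forward. The evidence so far is the limit of > 100000 nM in this assay, at which 2 of the 2 values shown sit.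

Compound 3 `COc1ccc(-c2cnc(NC(=O)c3cccc(F)c3)n2C)cc1` has 3-fluorophenyl in place of 4-methylphenyl on a carbonyl carbon. Within the data shown here, the only measured change at this carbonyl carbon, 4-methylphenyl in place of 1H-imidazol-2-yl, ended at a limit in this assay, and it gives no direction for the new change. No step beyond the usual scatter is therefore expected. The estimated step is a number no higher from compound 2 to compound 3 (the limit leaves the size open), with no direction claimed. Another limit would not be a surprise. The estimate for compound 3 is 100000 nM, with an expected range from 30000 nM to 200000 nM.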

Compound 3, half-maximal cytotoxic concentration: > 100000 nM
Compound 3: only a limit was reported; the forecaster's own chance of this, stated with the estimate: 80%; the middle value lies on the limit itself.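

In this assay compound 3 gives > 100000 nM, which is a limit and not a number. Within the data shown here, compound 1, compound 2 and compound 3 all stand at limits, and no step among them can be read. The compounds shown leave open what the actual values are, and whether any group on the carbonyl carbon changes how much compound is tolerated.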